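Notes on removing the methoxy group from compound 1

This account rests on a few compounds, and the source may have more. Where it says the series, first, only, none or still open, it means among the compounds named here.

Measured so far in a functional assay on K562 cells (Homo sapiens) for antiproliferative activity, read by MTT assay, with a stated time of 48 h; a lower number here means a stronger inhibitor, a higher number a weaker inhibitor
- compound 1 `COc1ccc(Nc2nc(Nc3cnn(CCCCCCC(=O)NO)c3)ncc2Cl)cc1` gives 620 nM
- compound 2 `O=C(CCCCCn1cc(Nc2ncc(Cl)c(Nc3cccc(Cl)c3)n2)cn1)NO` gives 580 nM

Among the measured compounds shown here, the values of compound 1 and compound 2 lie within the usual scatter of each other, so compound 1 cannot be separated from the only other compound measured. For the measured compounds named here, these two compounds do not form a single-change pair, and no measured step isolates any one structural feature.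

The next compound to be read is compound 3 `O=C(CCCCCCn1cc(Nc2ncc(Cl)c(Nc3ccccc3)n2)cn1)NO`. Its difference from compound 1 is hydrogen in place of methoxy on an aromatic carbon, para to a large group, which takes 4-methoxyphenyl to phenyl. The evidence for this change is thin. Going by the values given here, the only guide is compound 2, which has no methoxy group and gives 580 nM in this assay, within the scatter of compound 1 (620 nM). No change beyond the scatter is therefore expected in this assay, in either direction. The expected result is a small 1.1-fold lower number from compound 1 to compound 3 (0.05 log units; within the scatter) that cannot be told from repeat-measurement noise. Compound 3 is estimated at 550 nM (220 nM to 1400 nM).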

Compound 3, half-maximal inhibitory concentration: 420 nM
Compound 3: the middle estimate sits 1.3-fold (0.12 log units) above what was measured; the range from low to high includes it.
By their numbers in this assay, from the lowest: compounds 3, 2 and 1 (each within the scatter of the next).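

In this assay, among the compounds shown here, hydrogen in place of methoxy on an aromatic carbon, para to a large group, gives a 1.5-fold lower number from compound 1 to compound 3 (0.17 log units; within the scatter) and is the first single-change pair. This gives a direct reading at this position, where the earlier comparison with compound 2 could only be indirect, as compound 2 differs from compound 1 in more than one place. Taking 4-methoxyphenyl to phenyl, and so removing two heavy atoms and one hydrogen-bond acceptor, leaves a result that cannot be separated from repeat-measurement noise in this assay, and no measurement shown bears on the reason for this.

One step at one carbon leaves open whether another group in the same place, such as a hydroxyl, an amine or a carboxylic acid, would shift the number beyond the scatter. It also leaves open whether hydrogen in place of methoxy would read the same way with a shorter or longer chain on the shared core.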